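Trifluoromethyl Analogue Weighed Against Three Cytotoxicity Limits

A few compounds are considered here, and "the series" means these few. Any claim that something is new, unique, unknown or untested is made for them only; others in the source may bear on it.

Compound 2 `O=S(=O)(Nc1ccc(-c2nc3ccccc3o2)cc1)c1cccc(O)c1` was examined in an ADME assay on HEK293 cells (Homo sapiens) for cytotoxicity, read by resazurin assay, with a stated time of 48 h; on this read-out higher numbers stand for lower toxicity in this test and lower numbers for higher toxicity in this test. In this assay compound 2 did not reach a number and stopped at the limit of the test, recorded as > 100000 nM. Two related compounds differ from it only in the ring attached to the sulfonyl sulfur. Compound 1 `O=S(=O)(Nc1ccc(-c2nc3ccccc3o2)cc1)c1ccccc1Cl` carries a 2-chlorophenyl there, and in this assay compound 1 likewise ends at the limit, with > 100000 nM. Compound 3 `O=S(=O)(Nc1ccc(-c2nc3ccccc3o2)cc1)c1ccccc1F` carries a 2-fluorophenyl, and in this assay compound 3 also gives only the limit > 100000 nM. The three steps among them, a step that the two limits leave unreadable from compound 1 to compound 2, a step that the two limits leave unreadable from compound 1 to compound 3 and a step that the two limits leave unreadable from compound 2 to compound 3, cannot be given a size because the limit of > 100000 nM in this assay, at which 3 of the 3 values shown sit, leaves no number on either side to compare.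

The next compound, compound 4 `O=S(=O)(Nc1ccc(-c2nc3ccccc3o2)cc1)c1cccc(C(F)(F)F)c1`, changes compound 2 as follows: trifluoromethyl in place of hydroxy on an aromatic carbon. For the measured compounds named here, no measured step bears readably on this change, since none could be sized. Nothing among the three results suggests a move away from the limit, so the expectation is that the test again reports no number. Compound 4 is therefore expected to show about 100000 nM in this assay, with an estimated range from 40000 nM to 250000 nM. The expected step would be a number no higher from compound 2 to compound 4 (the limit leaves the size open).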

Compound 4, half-maximal cytotoxic concentration: > 100000 nM
Compound 4 gave a limit, no number; the forecaster's own chance of this, stated with the estimate: 75%; the middle value sits exactly at the limit.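

Compound 2 and compound 4 both end at a limit rather than a number, so the change from hydroxy to trifluoromethyl cannot be given a size, for this reason: the limit of > 100000 nM in this assay, at which 4 of the 4 values shown sit. The compounds shown leave open at what concentration, if any, each would become toxic in this assay, and whether these changes affect that concentration.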